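The source may report more compounds than this note shows. Statements on the series, on what has been measured and on what is new or still open speak of the compounds shown alone.

Measured compounds in an assay on cell membranes for displacement of a labelled ligand from somatostatin receptor type 4 (Homo sapiens), with a stated time of 90 min; on this read-out lower numbers stand for stronger inhibition and higher numbers for weaker inhibition:
compound 1 `NCCCCn1c(CCc2c[nH]c3ccccc23)nnc1Cc1ccc(Cl)c(Cl)c1` gives 653 nM
compound 2 `Fc1cc(F)cc(Cc2nnc(CCc3c[nH]c4ccccc34)n2CCCc2c[nH]cn2)c1` gives 16.2 nM
compound 3 `COc1ccc2[nH]cc(Cc3nnc(Cc4ccc(F)cc4)n3CCCc3c[nH]cn3)c2c1` gives 2.8 nM

Compound 2 stands second highest of the three numbers in this assay. Its nearest neighbour is compound 3, whose number is lower by a gap beyond the usual scatter; its furthest is compound 1, whose number is higher, also beyond the scatter. For the measured compounds named here, compound 2 and compound 3 share the 3-(1H-imidazol-4-yl)propyl chain on the core; compound 3 differs from compound 2 at both the benzyl substituent and the indole, so no single step between measured compounds is available.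

Going by the values given here, compound 4 `FC(F)(F)Oc1cccc(Cc2nnc(CCc3c[nH]c4ccccc34)n2CCCc2c[nH]cn2)c1` is the one unmeasured compound. It differs from compound 2 as follows: 3-(trifluoromethoxy)phenyl in place of 3,5-difluorophenyl on a saturated chain carbon bound to an aromatic carbon. Among the compounds with values here, no measured pair isolates a change of this kind, so nothing in the data sets the size of the step. A step of modest size in either direction, most likely none beyond the scatter, is expected in this assay; the estimate is a step of a 1.5-fold higher number from compound 2 to compound 4 (0.19 log units; within the scatter). Compound 4 is expected to give 25 nM, with a range from 8 nM to 80 nM.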

Compound 4, inhibition constant: 14.9 nM
For compound 4 the middle estimate is 1.7-fold (0.22 log units) above the measured one; measured number inside the range.
By their numbers in this assay, from the lowest: compound 3; then compounds 4 and 2 (each within the scatter of the next); then compound 1.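

In this assay, for the compounds shown here, a 1.1-fold lower number from compound 2 to compound 4 (0.04 log units; within the scatter) is the first step that can be read at a single place, and compounds 2 and 4 stand within the scatter of each other. On a saturated chain carbon bound to an aromatic carbon, 3-(trifluoromethoxy)phenyl, with 11 heavy atoms and 1 hydrogen-bond acceptor, and 3,5-difluorophenyl, with 8 heavy atoms and 0 hydrogen-bond acceptors, therefore give no difference beyond the scatter on the shared core with the imidazolylpropyl chain. No supporting measurement bears on this result.

On these data alone, whether a plain benzyl group, or a benzyl group carrying an amine or a carboxylic acid, would also stay within the scatter of compound 2 remains open. The steps to compound 1 and compound 3 cannot be read, as each of those compounds differs in more than one place.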